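From cyano to nitro on compound 1

The compounds below may be only part of what the source reports. "The series", "measured", "known", "first", "only" and "open" are said of these compounds alone.

Compound 1 `CC(O)(CSc1ccc(S(F)(F)(F)(F)F)cc1)C(=O)Nc1ccc(C#N)c(C(F)(F)F)c1` gives 16900 nM
Compound 2 `CC(O)(CSc1cccc(S(F)(F)(F)(F)F)c1)C(=O)Nc1ccc(C#N)c(C(F)(F)F)c1` gives 14500 nM

In a functional assay on LNCaP cells (Homo sapiens) for antiproliferative activity, read by propidium iodide staining, with a stated time of 96 h (a lower number here means a stronger inhibitor, a higher number a weaker inhibitor), compound 1 stands level with compound 2, as their two values lie within the scatter of each other. Compound 3 `CC(O)(CSc1ccc(S(F)(F)(F)(F)F)cc1)C(=O)Nc1ccc([N+](=O)[O-])c(C(F)(F)F)c1` keeps the core of compound 1 but has nitro in place of cyano on an aromatic carbon, ortho to a trifluoromethyl group and para to a large group (nitro in place of cyano on an aromatic carbon). Among the compounds with values here, no measured pair shows this change, so the data offer no direct guide. No step beyond the scatter is expected in this assay. The estimated step is a 1.1-fold lower number from compound 1 to compound 3 (0.05 log units; within the scatter) and stays within the scatter. Compound 3 is estimated at 15000 nM in a range from 6000 nM to 35000 nM as expected bounds.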

Compound 3, half-maximal inhibitory concentration: 8700 nM
Compound 3: the middle estimate sits 1.7-fold (0.24 log units) above what was measured; the range from low to high includes it.
By their numbers in this assay, from the lowest: compounds 3, 2 and 1 (each within the scatter of the next).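

In this assay, nitro in place of cyano on an aromatic carbon, ortho to a trifluoromethyl group and para to a large group, gives a 1.9-fold lower number from compound 1 to compound 3 (0.29 log units; within the scatter) and so no step beyond the scatter. Within the data shown here, this is the only measured pair at this position, and it shows that this one exchange leaves compound 3 level with compound 1. Nothing measured here accounts for the result.

From the compounds shown here alone, whether an amine or a carboxylic acid at this position would stay level with compound 1 remains open. So does the outcome of the same exchange on compound 2.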